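Adding a methyl to a brominated core: what to expect

The source may report more compounds than this note shows. Statements on the series, on what has been measured and on what is new or still open speak of the compounds shown alone.

Measured so far:
compound 1, `Cc1nc2c(Br)c(Br)c(Br)c(Br)c2n1CCCCC#N`, 42%
compound 2, `N#CCCn1cnc2c(Br)c(Br)c(Br)c(Br)c21`, 23%

Both compounds were tested in a functional assay on MCF7 cells (Homo sapiens) for cytotoxicity, read by MTT assay, with a stated time of 24 h, tested at 50 uM; on this read-out lower numbers stand for a stronger effect and higher numbers for a weaker effect at the one concentration tested. Compound 2 gives the lowest of the two numbers, 23%, which on this read-out means the stronger effect. Compound 1 gives 42%, a number higher by more than the usual scatter, so the two compounds are truly apart. Compound 1 and compound 2 differ in two places at once, so their values alone cannot say which change matters.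

The next compound, compound 3, is `Cc1nc2c(Br)c(Br)c(Br)c(Br)c2n1CCC#N`. It differs from compound 2 in one place only: methyl in place of hydrogen on an aromatic carbon.

Among the compounds with values here, no single measured step shows what this change does. Compound 1 carries the same methyl, and compound 1 gives 42%, but it also carries a different chain, so its number is not a clean guide. The expectation is therefore a modest shift upward, roughly a number 9 percentage points higher from compound 2 to compound 3 (within the scatter), without confidence in its direction. Compound 3 is expected to give about 32%, within a range of 15% to 50%.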

Compound 3, a percentage reported as activity, at one concentration (the size of the read-out at that concentration, not a potency): 15%
Compound 3: the middle estimate sits 17 percentage points above what was measured, and the stated range covers the measured number.
By their numbers in this assay, from the lowest: compounds 3 and 2 (each within the scatter of the next); then compound 1.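

Placing a methyl in place of hydrogen on the aromatic carbon between two ring nitrogen atoms gives a number 8 percentage points lower from compound 2 to compound 3 (within the scatter) in this assay, so this is the first clean reading of the change, and on this read-out compound 2 and compound 3 cannot be told apart. The methyl at this position is therefore tolerated, and the number does not follow the upward shift that compound 1 had hinted at. With the methyl present on both sides, the chain can also be read alone for the first time: a number 27 percentage points lower from compound 1 to compound 3 (beyond the scatter) is a real gap, so the higher number of compound 1 goes with its chain and not with the methyl, though nothing shown gives a reason for either step.

Still open, as far as these compounds go, is whether something other than methyl at this position, such as an ethyl group or an amine, would leave the number as undisturbed. From the compounds shown here alone, the chain is also read only from one pair, so it remains unknown how a carboxylic acid in place of the nitrile at the chain end, or a chain of another length, would fare on the same methyl-bearing core.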